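This account rests on a few compounds, and the source may have more. Where it says the series, first, only, none or still open, it means among the compounds named here.

Working notes on the series, all read in a functional assay on NCI-H460 cells (Homo sapiens) for cytotoxicity, read by MTT assay, with a stated time of 72 h; on this read-out higher numbers stand for weaker inhibition and lower numbers for stronger inhibition. Compound 2 `CCCCNC1=CC(=O)C=C(C(C)(C)C)C1=O` gives 13000 nM. Compound 3 `CC1=CCC[C@H]2[C@](C)(CC3=CC(=O)C=CC3=O)[C@@H](C)CC[C@]12C` gives 24000 nM, which lies within the scatter of the number for compound 2. Compound 1 `CCCCCCCCNC1=CC(=O)C=C(C[C@]2(C)[C@@H](C)CC[C@]3(C)C(C)=CCC[C@@H]23)C1=O` gives 35000 nM, which lies beyond the scatter of the number for compound 2.

Compound 4 `CC(C)(C)C1=CC(=O)C=C(NCc2ccccc2)C1=O` differs from compound 2 by phenyl in place of propyl on a saturated chain carbon bound to an amine nitrogen. Among the compounds with values here, no measured step makes this exchange. The nearest evidence is a 1.5-fold lower number from compound 1 to compound 3 (0.16 log units; within the scatter), with hydrogen in place of octylamino on a double-bonded ring carbon. That step stays within the scatter, but it bears only indirectly on the change at hand. No step beyond the scatter is therefore expected in this assay, and the expectation rests on compound 2 at 13000 nM. The expected size is a 1.1-fold lower number from compound 2 to compound 4 (0.03 log units; within the scatter), with no firm direction. For compound 4 the estimated value is 12000 nM, with an expected range from 6000 nM to 25000 nM.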

Compound 4, half-maximal inhibitory concentration: 10000 nM
Estimate against measurement, compound 4: 1.2-fold (0.08 log units) above, within the range that was stated.
By their numbers in this assay, from the lowest: compounds 4, 2, 3 and 1 (each within the scatter of the next, the first and the last beyond it).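

In this assay, the series now has a direct reading at a saturated chain carbon bound to an amine nitrogen, where phenyl replaces propyl: a 1.3-fold lower number from compound 2 to compound 4 (0.11 log units; within the scatter). The earlier compounds shown here offered only an indirect step, whereas this exchange shows that adding a six-membered aromatic ring at this place on the shared core produces no change beyond the scatter. No measurement at hand gives a reason for this result.

One exchange cannot show whether other groups at this place would also stay within the scatter, for example a carboxylic acid, an amine or a longer chain. As far as these compounds go, it also remains open how a phenyl ring carrying a hydroxyl group or a fluorine atom would read in this assay.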